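Chloro on the methyl-substituted member of the series

This account rests on a few compounds, and the source may have more. Where it says the series, first, only, none or still open, it means among the compounds named here.

Measured in a functional assay on MCF7 cells (Homo sapiens) for antiproliferative activity, read by MTT assay (a higher number here means a weaker inhibitor, a lower number a stronger inhibitor), so far:
- compound 1 `NS(=O)(=O)c1ccc(/N=C2\NC(=O)/C(=C3/C(=O)Nc4ccc(Cl)cc43)S2)cc1` gives 3960 nM
- compound 2 `NS(=O)(=O)c1ccc(/N=C2\NC(=O)/C(=C3/C(=O)N(Cc4ccccc4)c4ccc(Cl)cc43)S2)cc1` gives 124000 nM
- compound 3 `CN1C(=O)/C(=C2\S/C(=N/c3ccc(S(N)(=O)=O)cc3)NC2=O)c2ccccc21` gives 51900 nM

Compound 3 stands in the middle of the three numbers, with compound 2 higher and compound 1 lower, both gaps beyond the scatter. Compound 4 `CN1C(=O)/C(=C2\S/C(=N/c3ccc(S(N)(=O)=O)cc3)NC2=O)c2cc(Cl)ccc21` has chloro in place of hydrogen on an aromatic carbon of compound 3. Among the measured compounds shown here, the one measured step, a 31-fold higher number from compound 1 to compound 2 (1.50 log units; beyond the scatter), swaps benzyl for hydrogen on an amide-type nitrogen in a ring, so no measured step isolates the chloro change. It shows only how far two chloro compounds can differ. Compound 4 shares the chloro with compound 1 (3960 nM) and compound 2 (124000 nM), and its number is expected to fall between theirs. A modest move to a lower number is therefore expected, with the estimated step of a 2.4-fold lower number from compound 3 to compound 4 (0.37 log units; beyond the scatter) in this assay as a rough guide. The estimated value for compound 4 is 22000 nM with an expected range from 6000 nM to 80000 nM in this work.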

Compound 4, half-maximal inhibitory concentration: > 200000 nM
Compound 4: a limit, no number; the forecaster's own chance of this, stated with the estimate: 8%; middle value at least 9.0-fold (0.95 log units) away from the limit.
By their numbers in this assay, from the lowest: compound 1; then compound 3; then compound 2. At a limit, above all of these: compound 4.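

In this assay, among the compounds shown here, chloro in place of hydrogen on an aromatic carbon gives an at least 3.8-fold higher number from compound 3 to compound 4 (0.58 log units; beyond the scatter), the first isolated reading of this change, and it runs toward weaker inhibition. With chloro held fixed, methyl in place of hydrogen on the amide-type nitrogen gives an at least 50-fold higher number from compound 1 to compound 4 (1.70 log units; beyond the scatter), while an at least 1.6-fold higher number from compound 2 to compound 4 (0.20 log units; that floor lies within the scatter) leaves that pair unordered. Compound 4 reads as a limit, not a number: the limit of > 200000 nM in this assay, at which 1 of the 4 values shown sits.

Open: whether chloro moves the number the same way with hydrogen or benzyl on that nitrogen. From the compounds shown here alone, also open: whether fluoro, methoxy or an amine on the same aromatic carbon gives a lower number than hydrogen.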